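Swapping a Carboxymethyl Side Chain for Isopropyl

The source may hold more compounds than are shown below. What is called first, only, known or untested is meant among the compounds shown, and "the series" means these compounds.

Of the compounds shown here, three that share a common amide-linked scaffold have been tested in a functional assay on the whole organism (Tail, strain ICR) with Mus musculus as the target, in the tail flick test, with a stated time of 120 min, at a dose of 25 umol/kg by the oral route; on this read-out lower numbers stand for a weaker effect and higher numbers for a stronger effect at the one dose given. Compound 1 `CSCC[C@H](NC(=O)CN(c1ncnc2c1ncn2C1CCCCO1)C1CC1)C(=O)OCc1ccccc1` gives 28.7% in this assay. Compound 2 `C[C@H](NC(=O)CN(c1ncnc2c1ncn2C1CCCCO1)C1CC1)C(=O)OCc1ccccc1` gives 25.3%. Compound 3 `O=C(O)CC[C@H](NC(=O)CN(c1nc(Cl)nc2[nH]cnc12)C1CC1)C(=O)O`, whose core differs from that of the first two, gives 30.1%. Compound 3 therefore stands highest of the three numbers, but both other values lie within the usual scatter of it, so no order among the three can be claimed.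

Within the data shown here, only one measured step joins two compounds that differ in a single place: a number 3.4 percentage points lower from compound 1 to compound 2 (within the scatter). That step exchanged a side chain at the same kind of position as the change considered here, and the number did not move beyond the scatter.

Compound 4 `CC(C)C[C@H](NC(=O)CN(c1nc(Cl)nc2[nH]cnc12)C1CC1)C(=O)O` differs from compound 3 as follows: isopropyl in place of carboxymethyl on a saturated chain carbon, two bonds along the chain from an amide-type nitrogen and a carbonyl carbon. Among the measured compounds shown here, the one step that bears on this, a number 3.4 percentage points lower from compound 1 to compound 2 (within the scatter), stayed within the scatter, so no shift beyond the scatter is expected for this new side-chain exchange either. Compound 4 is accordingly estimated to give about 29% in this assay, with a range from 17% to 41%. The expected step is a number 1.1 percentage points lower from compound 3 to compound 4 (within the scatter).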

Compound 4, a percentage reported as activity, at one dose (the size of the read-out at that dose, not a potency): 18.7%
The estimate for compound 4 lay 10.3 percentage points above the measured number; low and high end bracket the measured number.
By their numbers in this assay, from the lowest: compounds 4, 2, 1 and 3 (each within the scatter of the next, the first and the last beyond it).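

In this assay, replacing carboxymethyl with isopropyl on the saturated chain carbon, two bonds along the chain from an amide-type nitrogen and a carbonyl carbon, gives a number 11.4 percentage points lower from compound 3 to compound 4 (beyond the scatter). Among these compounds, the earlier side-chain exchange at this kind of place, a number 3.4 percentage points lower from compound 1 to compound 2 (within the scatter), did not move the number beyond the scatter, so this result is the first sign that the read-out can respond to the group here, although that rests on this one pair on the core of compound 3. The carboxymethyl that leaves has 1 hydrogen-bond donor and 1 hydrogen-bond acceptor and the isopropyl that enters has 0 of either, but no measurement at hand connects that difference to the lower number.

As far as these compounds go, it remains open whether the carboxylic acid itself matters at this place, which a methyl ester, a primary amide or an amine in the same position could help to test, and whether a longer chain ending in a carboxylic acid would behave like compound 3. Also open, from the compounds shown here alone, is whether the same exchange on the core of compound 1 would give a step of similar size.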